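This account rests on a few compounds, and the source may have more. Where it says the series, first, only, none or still open, it means among the compounds named here.

Measured compounds:
- compound 1, `C[Se]/C(=N\C(=O)c1cc2ccccc2s1)NC(=O)c1cc2ccccc2s1` — 34700 nM
- compound 2, `CS/C(=N\C(=O)c1cc2ccccc2s1)NC(=O)c1cc2ccccc2s1` — 5600 nM
- compound 3, `O=C(/N=C(/NC(=O)c1ccno1)[Se]Cc1ccccc1)c1ccno1` — > 100000 nM

In an ADME assay on MCF-10A cells (Homo sapiens) for cytotoxicity, read by MTT assay, with a stated time of 72 h (a higher number here means a weaker inhibitor of growth, a lower number a stronger inhibitor of growth), compound 2 gives 5600 nM, the lowest of the two numbers that are numbers; compound 1 gives 34700 nM. For compound 3 only a limit is known, > 100000 nM, which is a limit of the assay and not a number (the limit of > 100000 nM in this assay, at which 1 of the 3 values shown sits).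

The unmeasured compound 4, `O=C(/N=C(/NC(=O)c1cc2ccccc2s1)[Se]Cc1ccccc1)c1cc2ccccc2s1`, arises from compound 2 by the change (a group of 8 heavy atoms (7 carbon, 1 selenium; one six-membered aromatic ring of carbon only) in place of a group of 2 heavy atoms (1 carbon, 1 sulfur; no ring), on a carbon with a double bond to nitrogen). Two things bear on this. First, the only measured step, a 6.2-fold lower number from compound 1 to compound 2 (0.79 log units; beyond the scatter), shows that exchanging selenium for sulfur on that carbon lowered the number; the change to compound 4 runs the other way, putting selenium back in, so the reverse of that step, a rise of similar size, is the first expectation. Second, compound 3 carries the same selenium-bearing group as compound 4 on a different shared core and shows only a limit; no step joins it to compound 2 or compound 4, so it gives a direction but no size.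

The expected step is therefore an 8.9-fold higher number from compound 2 to compound 4 (0.95 log units; beyond the scatter), a higher number for compound 4. Compound 4 is estimated at 50000 nM, within 15000 nM to 160000 nM, with a real chance that only a limit is reported.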

Compound 4, concentration for total growth inhibition: 62900 nM
For compound 4 the middle estimate is 1.3-fold (0.10 log units) below the measured one; the range from low to high includes it.
By their numbers in this assay, from the lowest: compound 2; then compounds 1 and 4 (each within the scatter of the next). At a limit, above all of these: compound 3.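

In this assay, the change on the carbon with a double bond to nitrogen gives a large rise, an 11-fold higher number from compound 2 to compound 4 (1.05 log units; beyond the scatter), so this position responds to a much bigger selenium-bearing group as well as to the exchange of sulfur for selenium seen earlier. The selenium pair separates the two parts of that change: phenyl in place of hydrogen on the saturated chain carbon bound to selenium gives a 1.8-fold higher number from compound 1 to compound 4 (0.26 log units; within the scatter), so in this pair the added phenyl has no readable effect, and the rise from compound 2 goes with the presence of selenium in place of sulfur. Nothing given here measures a property that would explain either step.

Open, as far as these compounds go, is whether this insensitivity holds for a longer chain on selenium or for an amine or carboxylic acid on the phenyl ring, and whether sulfur carrying the same phenyl-bearing chain would stay close to compound 2. Compound 3, at > 100000 nM, is a limit of the assay and not a number, and its core differs, so it gives no readable step.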